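The source may hold more compounds than are shown below. What is called first, only, known or untested is meant among the compounds shown, and "the series" means these compounds.

Measured so far in an ADME assay on MT4 cells (Homo sapiens) for cytotoxicity, read by MTT assay; a lower number here means that less compound is tolerated, a higher number that more compound is tolerated:
- compound 1 `COc1cccc2c1c(C(=O)/C=C(\O)C(=O)O)cn2Cc1ccc(F)c(F)c1F`: 22800 nM
- compound 2 `CCOC(=O)/C(O)=C/C(=O)c1cn(Cc2c(F)cccc2F)c2cccc(OC)c12`: 63400 nM
- compound 3 `COc1cccc2c1c(C(=O)/C=C(\O)C(=O)O)cn2Cc1c(F)cccc1F`: 44300 nM

Compound 3 and compound 1 share a core and differ only in the group on the aromatic nitrogen. The change is 2,3,4-trifluorophenyl in place of 2,6-difluorophenyl on a saturated chain carbon bound to an aromatic nitrogen. The step it made is a 1.9-fold lower number from compound 3 to compound 1 (0.29 log units; within the scatter), so on these two compounds the change has no resolved effect on the read-out.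

Compound 2 carries the other core. It differs from compound 3 by ethyl in place of hydrogen on an oxygen next to a carbonyl group. The step between them is a 1.4-fold lower number from compound 2 to compound 3 (0.16 log units; within the scatter), again within the scatter. Between compound 2 and compound 1 no single-point step is defined; their two values stand apart by somewhat more than the scatter allows, as the numbers above show.

Compound 4 `CCOC(=O)/C(O)=C/C(=O)c1cn(Cc2ccc(F)c(F)c2F)c2cccc(OC)c12` has not yet been measured in this assay. Relative to compound 2 it carries 2,3,4-trifluorophenyl in place of 2,6-difluorophenyl on a saturated chain carbon bound to an aromatic nitrogen. This is the same change as between compound 3 and compound 1, made on the same place, and the place is described in identical words for both pairs. Among the compounds with values here, the one measured instance of the change gave a step within the scatter. Within the data shown here, the expectation is therefore that the step from compound 2 to compound 4 is estimated at a 1.9-fold lower number from compound 2 to compound 4 (0.27 log units; within the scatter), resting on a 1.9-fold lower number from compound 3 to compound 1 (0.29 log units; within the scatter) as the only precedent. Compound 4 is expected to give about 34000 nM in this assay. Among the measured compounds shown here, the estimated range for compound 4 runs from 15000 nM to 80000 nM, wide because it rests on a 1.9-fold lower number from compound 3 to compound 1 (0.29 log units; within the scatter) as the single precedent and on a change of core.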

Compound 4, half-maximal cytotoxic concentration: 42700 nM
For compound 4 the middle estimate is 1.3-fold (0.10 log units) below the measured one, within the range that was stated.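

In this assay, 2,3,4-trifluorophenyl in place of 2,6-difluorophenyl on a saturated chain carbon bound to an aromatic nitrogen gives a 1.5-fold lower number from compound 2 to compound 4 (0.17 log units; within the scatter), and this reads alike on the two cores: the same change on two cores in this assay, a 1.9-fold lower number (0.29 log units; within the scatter) from compound 3 to compound 1 and a 1.5-fold lower number (0.17 log units; within the scatter) from compound 2 to compound 4, 1.3-fold (0.12 log units) apart, within the scatter of two such steps

Ethyl in place of hydrogen on an oxygen next to a carbonyl group gives a 1.9-fold higher number from compound 1 to compound 4 (0.27 log units; within the scatter), and this change also reads alike on the two cores: the same change on two cores in this assay, a 1.4-fold lower number (0.16 log units; within the scatter) from compound 2 to compound 3 and a 1.9-fold lower number (0.27 log units; within the scatter) from compound 4 to compound 1, 1.3-fold (0.12 log units) apart, within the scatter of two such steps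

Each change therefore carries from one core to the other without a resolved difference across these four compounds, but with every step inside the scatter, this shows only that no dependence on the core can be detected here, not that either change is without effect or that a larger step would carry in the same way.

The compounds shown leave open how an unsubstituted benzyl group, a chlorobenzyl group or a longer chain on the aromatic nitrogen would behave, and the same holds for an amide or a methyl ester in place of the ethyl ester. They also leave open whether a change with a step beyond the scatter would keep its size from one core to the other.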